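Moving a Fluorine Around the Aniline Ring

The compounds below may be only part of what the source reports. "The series", "measured", "known", "first", "only" and "open" are said of these compounds alone.

The measured compounds:
compound 1 `CC(=O)Nc1cccc(Oc2nc(NCC3CCOCC3)n3ncc(-c4ccc(C(=O)NC5CC5)c(C)c4)c3n2)c1` gives 1200 nM in a functional assay on OVCAR-3 cells (Homo sapiens) for antiproliferative activity; a higher number here means a weaker inhibitor of growth, a lower number a stronger inhibitor of growth
compound 2 `Cc1cc(-c2cnn3c(NCC4CCOCC4)nc(Oc4cccc(F)c4F)nc23)ccc1C(=O)NC1CC1` gives 37 nM in this assay
compound 3 `Cc1cc(-c2cnn3c(NCC4CCOCC4)nc(Nc4cccc(F)c4)nc23)ccc1C(=O)NC1CC1` gives 58 nM in this assay

Among these three numbers compound 3 holds the second highest. Its nearest neighbour is compound 2, with a 1.6-fold higher number from compound 2 to compound 3 (0.20 log units; within the scatter), a gap that the scatter of the method can account for. Compound 1 lies far away, with a 21-fold lower number from compound 1 to compound 3 (1.32 log units; beyond the scatter), and compound 2 is likewise far from compound 1, with a 32-fold lower number from compound 1 to compound 2 (1.51 log units; beyond the scatter).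

Compound 4 `Cc1cc(-c2cnn3c(NCC4CCOCC4)nc(Nc4ccccc4F)nc23)ccc1C(=O)NC1CC1` is the unmeasured partner. It differs from compound 3 by 2-fluorophenyl in place of 3-fluorophenyl on a nitrogen on an aromatic ring. The two share every atom; only the fluorine moves.

The step that bears most directly is that from compound 2 to compound 3, where the aryl group and its linking atom were both exchanged and the number hardly moved. The large steps from compound 1 concern a different group altogether and say little about shifting a single fluorine. Compound 4 is therefore expected to land close to compound 3, with a 1.1-fold higher number from compound 3 to compound 4 (0.05 log units; within the scatter) and no step beyond the scatter. The estimate for compound 4 is 65 nM, within a range from 25 nM to 170 nM.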

Compound 4, concentration for 50% growth inhibition: 190 nM
Beside the measured number, compound 4's estimate is 2.9-fold (0.47 log units) below it; the whole stated range lies below it.
By their numbers in this assay, from the lowest: compounds 2 and 3 (each within the scatter of the next); then compound 4; then compound 1.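

Moving the fluorine without changing any atom count is enough to shift the result in this assay (a 3.3-fold higher number from compound 3 to compound 4 (0.52 log units; beyond the scatter)), so this position tells 2-fluorophenyl apart from 3-fluorophenyl, which the earlier compounds, all differing by larger exchanges, could not show. The (2-fluorophenyl)amino group also separates from 2,3-difluorophenoxy (a 5.1-fold higher number from compound 2 to compound 4 (0.71 log units; beyond the scatter)), whereas (3-fluorophenyl)amino stayed within the scatter of that group, yet it still gives a lower number than 3-acetamidophenoxy (a 6.3-fold lower number from compound 1 to compound 4 (0.80 log units; beyond the scatter)), so the change weakens growth inhibition without reaching the level of compound 1. No measurement is available that accounts for the effect of moving the fluorine.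

Plain phenylamino, with no fluorine on the ring, would show whether 3-fluorophenyl lowers the number, 2-fluorophenyl raises it, or both contribute. The (2,3-difluorophenyl)amino group would show how the two fluorine placements behave together on the nitrogen, and 2-fluorophenoxy would show whether the same placement matters when the ring sits on an oxygen.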